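Changing One Aryl Group on a Shared Core

The source may report more compounds than this note shows. Statements on the series, on what has been measured and on what is new or still open speak of the compounds shown alone.

Of the compounds shown here, three built on one shared core have been measured in a functional assay on SK-MEL-5 cells (Homo sapiens) for antiproliferative activity, with a stated time of 48 h; on this read-out lower numbers stand for stronger inhibition of growth and higher numbers for weaker inhibition of growth. Compound 1 `Cc1cc(O)c(C2=NN(c3ccc(S(N)(=O)=O)cc3)C(c3ccccc3O)C2)cc1Cl` gives 5690 nM. Compound 2 `Cc1cc(O)c(C2=NN(c3ccc(S(N)(=O)=O)cc3)C(c3ccccc3Cl)C2)cc1Cl` gives 3850 nM. Compound 3 `Cc1cc(O)c(C2=NN(c3ccc(S(N)(=O)=O)cc3)C(/C=C/c3ccccc3)C2)cc1Cl` gives 4230 nM. Among these three numbers compound 3 holds the second highest, yet the gaps to its neighbours are small: the step of a 1.1-fold higher number from compound 2 to compound 3 (0.04 log units; within the scatter) and the step of a 1.3-fold lower number from compound 1 to compound 3 (0.13 log units; within the scatter) both stay inside the usual scatter, so none of the three can be called more or less active than another.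

Compound 4 `COc1ccc(C2CC(c3cc(Cl)c(C)cc3O)=NN2c2ccc(S(N)(=O)=O)cc2)cc1OC` is the next compound to be measured. It differs from compound 3 in one place: 3,4-dimethoxyphenyl in place of 2-phenylethenyl on a saturated ring carbon. Within the data shown here, two measured steps bear on this change, since they alter the same saturated ring carbon: a 1.3-fold lower number from compound 1 to compound 3 (0.13 log units; within the scatter) and a 1.1-fold higher number from compound 2 to compound 3 (0.04 log units; within the scatter). A third step, a 1.5-fold lower number from compound 1 to compound 2 (0.17 log units; within the scatter), swaps hydroxy for chloro on the aromatic ring carried by that carbon and is also within the scatter. Every change tried so far at this position has left this assay's read-out essentially unmoved, so the step of a 1.0-fold lower number from compound 3 to compound 4 (0.00 log units; within the scatter) is expected to stay within the scatter as well. Compound 4 is therefore estimated at 4200 nM, with a range from 1800 nM to 10000 nM.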

Compound 4, concentration for 50% growth inhibition: 4280 nM
Compound 4: middle estimate off by 1.0-fold (0.01 log units), on the low side; measured number inside the range.
By their numbers in this assay, from the lowest: compounds 2, 3, 4 and 1 (each within the scatter of the next).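

On this saturated ring carbon, next to the ring nitrogen, 3,4-dimethoxyphenyl brings 2 hydrogen-bond acceptors where 2-phenylethenyl has 0, yet in this assay the number barely shifts (a 1.0-fold higher number from compound 3 to compound 4 (0.01 log units; within the scatter)). The new group also stays level with the two substituted phenyl groups tried earlier, both 2-chlorophenyl (a 1.1-fold higher number from compound 2 to compound 4 (0.05 log units; within the scatter)) and 2-hydroxyphenyl (a 1.3-fold lower number from compound 1 to compound 4 (0.12 log units; within the scatter)), so the flat picture now extends to a larger group with two methoxy substituents, and none of the four compounds goes against it. No available measurement explains why this position responds so little.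

From the compounds shown here alone, all four groups at this carbon contain a six-membered aromatic ring of carbon only, so it remains open whether a group without such a ring, such as a simple amine, a carboxylic acid or a short alkyl chain, would move the number beyond the scatter. Going by these compounds, the 4-sulfamoylphenyl and 5-chloro-2-hydroxy-4-methylphenyl groups are the same in all four compounds, so what changes at those places would do to growth inhibition also remains open.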